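The source may hold more compounds than are shown below. What is called first, only, known or untested is meant among the compounds shown, and "the series" means these compounds.

Measured compounds, with their numbers in a functional assay on HCT-116 cells (Homo sapiens) for antiproliferative activity, with a stated time of 72 h; a lower number here means a stronger inhibitor, a higher number a weaker inhibitor:

Compound 1, `O=C(COc1ccc(CNC2CC=C(c3c[nH]c4ccc(F)cc34)CC2)c(F)c1)NO`: 261 nM
Compound 2, `Cc1ccc2[nH]cc(C3=CCN(Cc4ccc(OCC(=O)NO)cc4F)CC3)c2c1`: 1450 nM
Compound 3, `O=C(COc1ccc(CNC2CC=C(c3c[nH]c4ccccc34)CC2)c(F)c1)NO`: 436 nM

Compound 1 and compound 3 share a core and differ in one place, (hydrogen in place of fluoro on an aromatic carbon). The step of a 1.7-fold higher number from compound 1 to compound 3 (0.22 log units; within the scatter) is small. Compound 2 carries a different core; the difference between the cores of compound 1 and compound 2 is not broken down here. Of the three measured compounds, compound 2 gives the highest number in this assay, and its gaps to compound 1 and to compound 3 both lie beyond the scatter.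

Compound 4, `Cc1ccc2[nH]cc(C3=CCN(Cc4ccc(OCC(=O)NO)cc4)CC3)c2c1`, is not yet measured. It differs from compound 2 by hydrogen in place of fluoro on an aromatic carbon. This is the same kind of change as that from compound 1 to compound 3, but not the same: there the carbon sat in a fused system of two rings, meta to a fused ring and para to a fused ring, whereas here it sits in a six-membered aromatic ring of carbon only, ortho to a large group and meta to a (hydroxycarbamoyl)methoxy group. Among the compounds with values here, the step of a 1.2-fold higher number from compound 2 to compound 4 (0.07 log units; within the scatter) is expected to stay small, beside a 1.7-fold higher number from compound 1 to compound 3 (0.22 log units; within the scatter), because the only measured instance of this kind of change, a 1.7-fold higher number from compound 1 to compound 3 (0.22 log units; within the scatter), lies within the scatter. For compound 4 the estimate in this assay is 1700 nM, with a range of 750 nM to 3800 nM.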

Compound 4, half-maximal inhibitory concentration: 632 nM
Compound 4: the middle estimate sits 2.7-fold (0.43 log units) above what was measured; the measured number lies below the stated range.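

In this assay, hydrogen in place of fluoro gives a 2.3-fold lower number from compound 2 to compound 4 (0.36 log units; beyond the scatter), so on this core the compound without the fluoro group carries the lower number. Within the data shown here, the change therefore does not carry over as a fixed step from one core to the other: the same change on two cores in this assay, a 1.7-fold higher number (0.22 log units; within the scatter) from compound 1 to compound 3 and a 2.3-fold lower number (0.36 log units; beyond the scatter) from compound 2 to compound 4, 3.8-fold (0.58 log units) apart, beyond the scatter of two such steps This shows that a step read on one compound of the series cannot simply be transferred to another, but it does not show what in the cores sets the difference, since each core supplies only one pair and the fluoro group leaves a different aromatic carbon in each.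

The compounds shown leave open whether fluoro on the same aromatic carbon would give the same step on both cores. They also leave open how a chloro group or a nitrile on that carbon would compare with hydrogen and fluoro.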